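Swapping Benzyl for 3-Methylphenyl on the Shared Core

A few compounds are considered here, and "the series" means these few. Any claim that something is new, unique, unknown or untested is made for them only; others in the source may bear on it.

Compound 1 `Cc1cc(C(=O)Nc2cc(Cl)cc(Cl)c2)nn1Cc1ccccc1` was tested in an assay on HEK293 cells for binding affinity to Neuropeptide Y receptor type 5 (Homo sapiens), read by radioligand binding; on this read-out higher numbers stand for weaker inhibition and lower numbers for stronger inhibition. In this assay compound 1 gives > 1000 nM, which is a limit of the assay and not a number. Compound 2 `Cc1cc(C(=O)Nc2cc(Cl)cc(Cl)c2)nn1-c1ccccc1C(F)(F)F` also gives only a limit, > 1000 nM. Compound 3 `Cc1cc(C(=O)Nc2cc(Cl)cc(Cl)c2)nn1-c1ccc(C(F)(F)F)cc1` likewise gives a limit, > 1000 nM. Compound 1 thus stands at the limit of > 1000 nM in this assay, at which 3 of the 3 values shown sit, with no measured number to compare against. Compound 4 `Cc1cccc(-n2nc(C(=O)Nc3cc(Cl)cc(Cl)c3)cc2C)c1` differs from compound 1 by 3-methylphenyl in place of benzyl on an aromatic nitrogen. Among the measured compounds shown here, no step between measured compounds is known, so no direction can be read from the data. The step from compound 1 to compound 4 is expected to be a step that the limit leaves unreadable from compound 1 to compound 4, probably within the scatter. Compound 4 is expected to give about 2000 nM, within a range from 500 nM to 10000 nM.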

Compound 4, half-maximal inhibitory concentration: 218 nM
Beside the measured number, compound 4's estimate is 9.2-fold (0.96 log units) above it, and the stated range ends above it.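

On the aromatic nitrogen, 3-methylphenyl in place of benzyl gives an at least 4.5-fold lower number from compound 1 to compound 4 (0.66 log units; beyond the scatter). This shows that a change at this one position can bring a compound on the shared core into the measurable range of this assay. Of the compounds shown, only compound 4 gives a number, and the others stay at a limit of the assay: the limit of > 1000 nM in this assay, at which 3 of the 4 values shown sit.

From the compounds shown here alone, compound 1 gives a limit and not a number, so the full size of the step remains open. Also open, going by these compounds, is how a methoxy group or a chlorine would read in place of the methyl group of the 3-methylphenyl.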